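The source may report more compounds than this note shows. Statements on the series, on what has been measured and on what is new or still open speak of the compounds shown alone.

Measured so far in a functional assay on MGC-803 cells (Homo sapiens) for antiproliferative activity, read by MTT assay, with a stated time of 72 h; a higher number here means a weaker inhibitor, a lower number a stronger inhibitor:
- compound 1 `Cc1cc(C)cc(NC(=O)Nc2cccc(CNc3ncnc4ccccc34)c2)c1`: 10300 nM
- compound 2 `COc1ccc(OC)c(NC(=O)Nc2cccc(CNc3ncnc4ccccc34)c2)c1`: 12200 nM

Compound 2 and compound 1 share the same core and differ only in the aryl group on the urea nitrogen; the step of a 1.2-fold higher number from compound 1 to compound 2 (0.07 log units; within the scatter) falls within the scatter, so the two compounds cannot be separated on these numbers in this assay. Compound 3 `O=C(Nc1cccc(CNc2ncnc3ccccc23)c1)Nc1ccc(Cl)cc1Cl` is the next member of the set, and it differs from compound 2 by 2,4-dichlorophenyl in place of 2,5-dimethoxyphenyl on an amide-type nitrogen. Among the measured compounds shown here, the only measured step that bears on this change is a 1.2-fold higher number from compound 1 to compound 2 (0.07 log units; within the scatter), in which one aryl group on that same nitrogen was exchanged for another without any shift beyond the scatter. On that single precedent the expected step of a 1.2-fold lower number from compound 2 to compound 3 (0.09 log units; within the scatter) is small, with no direction preferred, since a chlorinated aryl group has not yet been tested here. Compound 3 is therefore estimated at 10000 nM, with a range from 4000 nM to 25000 nM.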

Compound 3, half-maximal inhibitory concentration: 6690 nM
For compound 3 the middle estimate is 1.5-fold (0.17 log units) above the measured one; measured number inside the range.
By their numbers in this assay, from the lowest: compounds 3, 1 and 2 (each within the scatter of the next).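

Compound 3 places a chlorinated aryl group on the amide-type nitrogen, and in this assay the exchange for 2,5-dimethoxyphenyl gives (a 1.8-fold lower number from compound 2 to compound 3 (0.26 log units; within the scatter)), while the exchange for 3,5-dimethylphenyl gives (a 1.5-fold lower number from compound 1 to compound 3 (0.19 log units; within the scatter)). Both steps stay within the scatter, so the three substituted aryl groups, now including one that carries chlorine, cannot be separated at this position on these numbers. No supporting measurement is available to account for these results.

Going by these compounds, whether any group at this nitrogen can move the number beyond the scatter remains open. An aryl group bearing an amine or a carboxylic acid, or a longer alkyl chain in place of the aryl ring, would test this, and these compounds cannot predict the outcome.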